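Moving the Fluoro Group Around a Phenyl Ring

The source may report more compounds than this note shows. Statements on the series, on what has been measured and on what is new or still open speak of the compounds shown alone.

Compound 1 `COc1ccc2nc(C)cc(NCc3ccccc3)c2c1` and compound 2 `COc1ccc2nc(C)cc(NCc3cccc(F)c3)c2c1` share one core. In a functional assay on MCF-10A cells (Homo sapiens) for antiproliferative activity, with a stated time of 48 h (a lower number here means that less compound is needed, a higher number that more compound is needed for the effect), compound 1 gives 28600 nM as its result and compound 2 gives 14700 nM as its result. Within the data shown here, the only measured step is a 1.9-fold lower number from compound 1 to compound 2 (0.29 log units; within the scatter) and it replaces hydrogen with fluoro on an aromatic carbon. On these numbers, compound 2 cannot be told apart from compound 1.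

Compound 3 `COc1ccc2nc(C)cc(NCc3ccccc3F)c2c1` has the same atoms as compound 2, joined differently. It carries 2-fluorophenyl in place of 3-fluorophenyl on a saturated chain carbon bound to a nitrogen on an aromatic ring and nothing else changes.

Among the measured compounds shown here, no measured step shows what happens when fluoro changes place, so the step that brought it in is the only guide. That step, a 1.9-fold lower number from compound 1 to compound 2 (0.29 log units; within the scatter), did not exceed the scatter, so no shift beyond the scatter is expected in this assay here. The estimated step is a 1.2-fold higher number from compound 2 to compound 3 (0.09 log units; within the scatter) and that is a small one. The expected value for compound 3 is 18000 nM with an estimated range from 8000 nM to 40000 nM for the coming measurement.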

Compound 3, half-maximal effective concentration: 17000 nM
For compound 3 the middle estimate is 1.1-fold (0.02 log units) above the measured one, and the stated range covers the measured number.
By their numbers in this assay, from the lowest: compounds 2, 3 and 1 (each within the scatter of the next).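

Moving the fluoro group to give 2-fluorophenyl in place of 3-fluorophenyl, on a saturated chain carbon bound to a nitrogen on an aromatic ring, gives in this assay a 1.2-fold higher number from compound 2 to compound 3 (0.06 log units; within the scatter), so these two placements cannot be told apart in this test. Set against the ring without fluoro, the new placement gives a 1.7-fold lower number from compound 1 to compound 3 (0.23 log units; within the scatter), and this step also stays within the scatter, so compound 3 joins compound 2 in showing no clear difference from compound 1. Taken together, the three compounds show no measurable sensitivity to either adding the fluoro group or changing its place on this ring, and no supporting measurement is available to explain this result.

From the compounds shown here alone, these compounds carry only hydrogen or fluoro on this ring, so it remains open whether a larger change, such as an amine or a carboxylic acid there, would give a step beyond the scatter. Going by these compounds, it also remains open whether a longer chain in place of the saturated chain carbon would change the number in this assay.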